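The source may report more compounds than this note shows. Statements on the series, on what has been measured and on what is new or still open speak of the compounds shown alone.

Measured in a functional assay on A549 cells (Homo sapiens) for antiproliferative activity, with a stated time of 72 h; on this read-out higher numbers stand for weaker inhibition and lower numbers for stronger inhibition:
- compound 1 `O=C(COc1ccc(CNC2CC=C(c3c[nH]c4cccc(F)c34)CC2)c(F)c1)NO`: 203 nM
- compound 2 `O=C(COc1ccc(CNC2CC=C(c3c[nH]c4ccccc34)CC2)c(F)c1)NO`: 278 nM

Among the measured compounds shown here, compound 1 and compound 2 lie within the scatter of each other, so compound 1 stands level with the only other number in this assay.

Compound 3 `Cc1[nH]c2cccc(F)c2c1C1=CCC(NCc2ccc(OCC(=O)NO)cc2F)CC1` differs from compound 1 by methyl in place of hydrogen on an aromatic carbon of a five-membered aromatic ring with 1 nitrogen, next to the ring nitrogen and next to the ring atom that bears a large group.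

For the measured compounds named here, the only measured step, a 1.4-fold higher number from compound 1 to compound 2 (0.14 log units; within the scatter), is a change of hydrogen in place of fluoro elsewhere on the core and stays within the scatter. Going by the values given here, no measured compound tests a methyl at this place, so the direction remains open and only a modest shift is expected, with no step clearly beyond the scatter.

The estimated step is a 1.2-fold higher number from compound 1 to compound 3 (0.09 log units; within the scatter).

For compound 3 the expected value is 250 nM, with an estimated range of 80 nM to 800 nM.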

Compound 3, half-maximal inhibitory concentration: 244 nM
Estimate against measurement, compound 3: 1.0-fold (0.01 log units) above; low and high end bracket the measured number.
By their numbers in this assay, from the lowest: compounds 1, 3 and 2 (each within the scatter of the next).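

In this assay, among the compounds shown here, methyl in place of hydrogen gives a 1.2-fold higher number from compound 1 to compound 3 (0.08 log units; within the scatter), the first reading at this place: on an aromatic carbon of the five-membered aromatic ring with 1 nitrogen, next to the ring nitrogen and next to the ring atom that bears a large group. This place therefore takes a methyl without a step beyond the scatter, just as the change elsewhere on the core, a 1.4-fold higher number from compound 1 to compound 2 (0.14 log units; within the scatter), stays within it. No measured property bears on this result.

Going by these compounds, whether a larger group at this place, such as a phenyl ring, or a charged one, such as an amine or a carboxylic acid, would give a step beyond the scatter remains open. Also open, on these data alone, is whether the methyl would read the same with hydrogen in place of fluoro on the shared core.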